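Replacing trifluoromethyl with bromo in compound 3

The compounds below may be only part of what the source reports. "The series", "measured", "known", "first", "only" and "open" are said of these compounds alone.

In a functional assay on HepG2 cells (Homo sapiens) for antiproliferative activity, read by MTT assay, with a stated time of 24 h (a lower number here means a stronger inhibitor, a higher number a weaker inhibitor), the measured values are:
compound 1 `COc1cc(OC)c(-c2coc3cc(OCc4ccccc4F)ccc3c2=O)cc1OC`: 1280 nM
compound 2 `COc1cc(OC)c(-c2coc3cc(OCc4ccc(F)cc4)ccc3c2=O)cc1OC`: 1000 nM
compound 3 `COc1cc(OC)c(-c2coc3cc(OCc4ccccc4C(F)(F)F)ccc3c2=O)cc1OC`: 6550 nM

Compound 3 has the highest number of the three, so it is the weakest inhibitor here. Compound 4 `COc1cc(OC)c(-c2coc3cc(OCc4ccccc4Br)ccc3c2=O)cc1OC` differs from it in one group (bromo in place of trifluoromethyl on an aromatic carbon), with bromo in place of trifluoromethyl on an aromatic carbon. The closest measured change is trifluoromethyl replacing fluoro (a 5.1-fold higher number from compound 1 to compound 3 (0.71 log units; beyond the scatter)), and a similar rise appears in another measured step (a 6.6-fold higher number from compound 2 to compound 3 (0.82 log units; beyond the scatter)). Bromo and fluoro are both halogens, so part of that rise may be won back. The expected change is moderate and downward (a 2.3-fold lower number from compound 3 to compound 4 (0.37 log units; beyond the scatter)). Compound 4 is estimated at 2800 nM (expected range 1100 nM to 6500 nM).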

Compound 4, half-maximal inhibitory concentration: 2180 nM
Compound 4: middle estimate off by 1.3-fold (0.11 log units), on the high side; low and high end bracket the measured number.
By their numbers in this assay, from the lowest: compounds 2, 1 and 4 (each within the scatter of the next, the first and the last beyond it); then compound 3.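

In this assay, the rise seen with trifluoromethyl on this aromatic carbon does not carry over to bromo: the change gives a 3.0-fold lower number from compound 3 to compound 4 (0.48 log units; beyond the scatter), while a 1.7-fold higher number from compound 1 to compound 4 (0.23 log units; within the scatter) leaves bromo and fluoro indistinguishable here. The step with 2-bromophenyl in place of 4-fluorophenyl gives a 2.2-fold higher number from compound 2 to compound 4 (0.34 log units; beyond the scatter), but it does not separate the effect of the halogen from that of its place on the ring. Nothing available explains these differences. From the compounds shown here alone, whether 4-bromophenyl would match 4-fluorophenyl remains open, as does how an amine or a carboxylic acid on this carbon would compare.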